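A few compounds are considered here, and "the series" means these few. Any claim that something is new, unique, unknown or untested is made for them only; others in the source may bear on it.

Measured in an ADME assay on microsomes from liver (Mus musculus) for metabolic stability, read by LC-MS, with NADPH named in the record, with a stated time of 60 min, tested at 1 uM, in the absence of a further agent (on this read-out higher numbers stand for a more stable compound and lower numbers for a less stable compound), with both values being limits of the assay and not numbers:

Compound 1 `COc1ccc(-c2c(C)nc3c(N4CC[C@@H](NC(C)=O)C4)cc(C)nn23)cn1`: > 95%
Compound 2 `COc1ccc(-c2c(C)nc3c(N4CC[C@@H](NC(=O)COc5ccccc5)C4)cc(C)nn23)cc1OC`: > 95%

Compound 2 therefore stands at a limit, the same one reached by compound 1: the limit of > 95% in this assay, at which 2 of the 2 values shown sit. Compound 3 `COc1ccc(-c2c(C)nc3c(N4CC[C@@H](NC(=O)Oc5cccc(C)c5)C4)cc(C)nn23)cc1OC` carries 3-methylphenoxy in place of phenoxymethyl on a carbonyl carbon. Within the data shown here, no measured step between compounds shows what such a change does in this assay, so only a modest fall is expected, and this estimate is uncertain: a number at least 15 percentage points lower from compound 2 to compound 3 (beyond the scatter). For compound 3 the expected value is 80%, within an estimated range of 50% to 98%.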

Compound 3, percent of the compound remaining: > 95%
Compound 3: only a limit was reported; the forecaster's own chance of this, stated with the estimate: 35%; middle value at least 15 percentage points from the limit.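

In this assay, among these compounds, compound 3 gives > 95%, a limit and not a number, and compound 2 stands at the same limit, so no step between them can be read. The compounds shown leave open whether 3-methylphenoxy in place of phenoxymethyl changes stability at all, with every value at one limit: the limit of > 95% in this assay, at which 3 of the 3 values shown sit.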